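Lengthening the linker and swapping the triazole substituent

This account rests on a few compounds, and the source may have more. Where it says the series, first, only, none or still open, it means among the compounds named here.

Three compounds share a core built around a methoxyphenyl-piperazine unit joined through a benzyl group to an aryl ether bearing a 1,2,3-triazole. Compound 1, `COc1cc(CN2CCN(c3ccccc3OC)CC2)ccc1OCCCc1cn(CCCCCCCCCCn2cc(CCCOc3ccc(CN4CCN(c5ccccc5OC)CC4)cc3OC)nn2)nn1`, pairs two such units through a long decyl chain; compound 2, `COc1cc(CN2CCN(c3ccccc3OC)CC2)ccc1OCc1cn(CCOCCOCCn2cc(COc3ccc(CN4CCN(c5ccccc5OC)CC4)cc3OC)nn2)nn1`, pairs them through a chain of ether oxygens. Compound 3, `CCCCn1cc(COc2ccc(CN3CCN(c4ccccc4OC)CC3)cc2OC)nn1`, carries a single unit with a butyl group on the triazole.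

In an assay on CHO cells for displacement of a labelled ligand from D(4) dopamine receptor (Homo sapiens) (a lower number here means a stronger inhibitor, a higher number a weaker inhibitor), compound 1 gives 19 nM, compound 2 gives 6.8 nM, and compound 3 gives 3.3 nM. Compound 3 has the lowest of the three numbers, and its gaps to compound 2 and to compound 1 both lie beyond the usual scatter.

Compound 4, `CCOCCn1cc(CCCOc2ccc(CN3CCN(c4ccccc4OC)CC3)cc2OC)nn1`, has not yet been measured in this assay. It differs from compound 3 by 2-(1-(2-ethoxyethyl)-1H-1,2,3-triazol-4-yl)ethyl in place of 1-butyl-1H-1,2,3-triazol-4-yl on a saturated chain carbon bound to an oxygen on an aromatic ring, so the chain between the triazole and the ether oxygen grows longer and an ethoxyethyl group replaces the butyl group.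

For the measured compounds named here, no measured pair shows this exact change. The step of a 1.8-fold higher number from compound 3 to compound 4 (0.26 log units; within the scatter) is expected to be small, toward a slightly higher number, close to the scatter. For compound 4 the estimated value in this assay is 6 nM, with a range from 2 nM to 20 nM.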

Compound 4, inhibition constant: 6.4 nM
Estimate against measurement, compound 4: 1.1-fold (0.03 log units) below; the range from low to high includes it.
By their numbers in this assay, from the lowest: compounds 3, 4 and 2 (each within the scatter of the next, the first and the last beyond it); then compound 1.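

In this assay, a 1.9-fold higher number from compound 3 to compound 4 (0.29 log units; within the scatter) shows that this position accepts a larger group, the 2-(1-(2-ethoxyethyl)-1H-1,2,3-triazol-4-yl)ethyl group in place of 1-butyl-1H-1,2,3-triazol-4-yl, without a change beyond the scatter. For the compounds shown here, the earlier compounds gave no such one-place comparison, so this is the first direct reading of a change at this site. The new group also brings an oxygen into the chain on the triazole and lengthens the chain to the ether oxygen, yet the two changes arrive together and their separate contributions cannot be read.

The compounds shown leave open how a butyl group would behave on the longer chain, and whether an amine or a carboxylic acid at the end of the ethoxyethyl chain would be accepted as well. Nothing shown gives a measured reason for this result.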